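Working notes on compound 3 to compound 4

The compounds below may be only part of what the source reports. "The series", "measured", "known", "first", "only" and "open" are said of these compounds alone.

Compound 1 `Cc1cc(N2CCCC2=O)c2ncc(CSCCc3ccccc3)n2c1` gives 25 ug/mL in an ADME assay on HEL cells (Homo sapiens) for cytotoxicity, with a stated time of 3 days; on this read-out higher numbers stand for lower toxicity in this test and lower numbers for higher toxicity in this test; compound 2 `Cc1cc(-n2cccc2)c2ncc(CSCCc3ccccc3)n2c1` gives 26 ug/mL in this assay, and compound 3 `Cc1cc(-n2ccnc2)c2ncc(CSCCc3ccccc3)n2c1` gives 10 ug/mL in this assay. Compound 3 therefore holds the lowest number of the three: the steps of a 2.5-fold lower number from compound 1 to compound 3 (0.40 log units; beyond the scatter) and a 2.6-fold lower number from compound 2 to compound 3 (0.41 log units; beyond the scatter) both lie beyond the scatter, while a 1.0-fold higher number from compound 1 to compound 2 (0.02 log units; within the scatter) does not. Compound 4 `Cc1cc(-n2ccc3cccnc32)c2ncc(CSCCc3ccccc3)n2c1` is reached from compound 3 by a group of 9 heavy atoms (7 carbon, 2 nitrogen; one five-membered aromatic ring with 1 hetero atom, one six-membered aromatic ring with 1 hetero atom) in place of a group of 5 heavy atoms (3 carbon, 2 nitrogen; one five-membered aromatic ring with 2 hetero atoms), on an aromatic carbon. Within the data shown here, no measured step exchanges a group of this kind; the only steps that bear on the position are those introducing the 1H-imidazol-1-yl group, which carried lower numbers. A modest rise back toward the numbers of compound 1 and compound 2 is expected, a 1.8-fold higher number from compound 3 to compound 4 (0.26 log units; within the scatter). Compound 4 is estimated at 18 ug/mL, within a range of 7 ug/mL to 45 ug/mL.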

Compound 4, half-maximal cytotoxic concentration: > 100 ug/mL
Compound 4 ended at the assay's limit; the forecaster's own chance of this, stated with the estimate: 10%; middle value at least 5.5-fold (0.74 log units) from the limit.
By their numbers in this assay, from the lowest: compound 3; then compounds 1 and 2 (each within the scatter of the next). At a limit, above all of these: compound 4.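

Compound 4 gives a limit of the read-out rather than a number: the limit of > 100 ug/mL in this assay, at which 1 of the 4 values shown sits. Even so, the group of 9 heavy atoms on this aromatic carbon gives an at least 10-fold higher number from compound 3 to compound 4 (1.00 log units; beyond the scatter), an at least 3.8-fold higher number from compound 2 to compound 4 (0.58 log units; beyond the scatter) and an at least 4.0-fold higher number from compound 1 to compound 4 (0.60 log units; beyond the scatter). The groups with a single five-membered ring at this position had differed only by modest steps, so this position tolerates a larger change in the read-out than they showed.

The compounds shown leave open how far past the limit compound 4 lies, and whether the six-membered aromatic ring or its nitrogen carries the change. From the compounds shown here alone, how an amine or a carboxylic acid on this carbon would read also stays open.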